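Swapping Trimethoxyphenyl for Benzyl: Expected Cytotoxicity Shift

The compounds below may be only part of what the source reports. "The series", "measured", "known", "first", "only" and "open" are said of these compounds alone.

In a functional assay on A549 cells (Homo sapiens) for cytotoxicity, read by MTT assay, with a stated time of 48 h (on this read-out higher numbers stand for weaker inhibition and lower numbers for stronger inhibition), compound 3 `COc1cc(N/C(CCNC2=CC(=O)c3ccccc3C2=O)=N\S(=O)(=O)c2ccc(C)cc2)cc(OC)c1OC` gives 7940 nM, the lowest of the three numbers recorded. Compound 1 `Cc1ccc(S(=O)(=O)/N=C(/CCNC2=CC(=O)c3ccccc3C2=O)Nc2ccccc2I)cc1` gives 24700 nM, and compound 2 `COc1ccc(N/C(CCNC2=CC(=O)c3ccccc3C2=O)=N\S(=O)(=O)c2ccc(C)cc2)cc1OC` gives 20500 nM. Compound 4 `Cc1ccc(S(=O)(=O)/N=C(/CCNC2=CC(=O)c3ccccc3C2=O)NCc2ccccc2)cc1` is not yet measured; it differs from compound 3 by benzyl in place of 3,4,5-trimethoxyphenyl on an amine nitrogen. Going by the values given here, two measured steps bear on this change: a 3.1-fold lower number from compound 1 to compound 3 (0.49 log units; beyond the scatter) and a 2.6-fold lower number from compound 2 to compound 3 (0.41 log units; beyond the scatter), both showing that the methoxy-bearing ring gave lower numbers than the alternatives tried. Removing all three methoxy groups and putting benzyl in place of the aryl ring has no direct precedent among these compounds, so the step is expected to run the other way, roughly undoing those gains: a 2.5-fold higher number from compound 3 to compound 4 (0.40 log units; beyond the scatter). Compound 4 is therefore expected to give about 20000 nM, within a range of 7000 nM to 60000 nM.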

Compound 4, half-maximal inhibitory concentration: 7410 nM
Estimate against measurement, compound 4: 2.7-fold (0.43 log units) above; measured number inside the range.
By their numbers in this assay, from the lowest: compounds 4 and 3 (each within the scatter of the next); then compounds 2 and 1 (each within the scatter of the next).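

In this assay, benzyl in place of 3,4,5-trimethoxyphenyl on the amine nitrogen gives a 1.1-fold lower number from compound 3 to compound 4 (0.03 log units; within the scatter), so methoxy groups are not needed to reach the lowest numbers in this set. Benzyl also gives a 2.8-fold lower number from compound 2 to compound 4 (0.44 log units; beyond the scatter) and a 3.3-fold lower number from compound 1 to compound 4 (0.52 log units; beyond the scatter), which places this group without methoxy level with the best aryl group shown and ahead of the other two. No measured evidence accounts for this. The compounds shown leave open how a longer chain ending in phenyl, or a benzyl group carrying methoxy, would read on this amine nitrogen.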